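This account rests on a few compounds, and the source may have more. Where it says the series, first, only, none or still open, it means among the compounds named here.

Values measured so far in a functional assay on HepG2 cells (Homo sapiens) for antiproliferative activity, read by MTT assay, with a stated time of 24 h; on this read-out higher numbers stand for weaker inhibition and lower numbers for stronger inhibition
- compound 1 `Cc1ccccc1CSc1nnc(-c2ccc3c(c2)OCCO3)n1-c1ccccc1` gives 20500 nM
- compound 2 `Fc1cccc(F)c1CSc1nnc(-c2ccc3c(c2)OCCO3)n1-c1ccccc1` gives 2070 nM

Compound 2 holds the lower of the two numbers, which makes it the stronger inhibitor of this pair. Compound 3 `Brc1ccccc1CSc1nnc(-c2ccc3c(c2)OCCO3)n1-c1ccccc1` is not yet measured. It differs from compound 2 by one change on a saturated chain carbon bound to a sulfur, with 2-bromophenyl in place of 2,6-difluorophenyl on a saturated chain carbon bound to a sulfur and the shared core stays the same.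

For the measured compounds named here, one measured step bears on this place, namely a 9.9-fold lower number from compound 1 to compound 2 (1.00 log units; beyond the scatter) when 2,6-difluorophenyl replaced 2-methylphenyl. That step is modest but beyond the scatter. The group in compound 3 is named like the 2-methylphenyl of compound 1 with its 20500 nM in carrying one group on the phenyl rather than two, so some of that loss may return. Going by the values given here, no measured compound contains bromine, and this makes the guess a loose one.

The expected change is a 2.9-fold higher number from compound 2 to compound 3 (0.46 log units; beyond the scatter) toward weaker inhibition, smaller than the measured step. Compound 3 is estimated at 6000 nM within a range of 1800 nM to 20000 nM on this read-out.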

Compound 3, half-maximal inhibitory concentration: 4730 nM
Compound 3: middle estimate off by 1.3-fold (0.10 log units), on the high side; the range from low to high includes it.
By their numbers in this assay, from the lowest: compound 2; then compound 3; then compound 1.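

In this assay, two groups that each carry one substituent on the phenyl ring do not read alike: bromo in place of methyl on an aromatic carbon gives a 4.3-fold lower number from compound 1 to compound 3 (0.64 log units; beyond the scatter). So at this place, the identity of the single group matters, and not only the number of groups on the ring. The 2-bromophenyl group still falls short of the 2,6-difluorophenyl group, with a 2.3-fold higher number from compound 2 to compound 3 (0.36 log units; beyond the scatter), which leaves compound 3 in the middle of the three and compound 2 with the lowest number; nothing available here explains this order.

These compounds leave open how a plain unsubstituted phenyl or a 2-fluorophenyl group would read at this place, and either would help separate the presence of a halogen from the presence of two fluorines. Also open, as far as these compounds go, is whether the same order would hold if the saturated chain carbon bound to the sulfur were extended to a longer chain.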